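The source may report more compounds than this note shows. Statements on the series, on what has been measured and on what is new or still open speak of the compounds shown alone.

Of the compounds shown here, three built on one shared core have so far been measured in a functional assay on P388 cells (Mus musculus) for inhibition, read by MTT assay, with a stated time of 72 h; a lower number here means a stronger inhibitor, a higher number a weaker inhibitor. Compound 1 `O=C(Nc1ccccc1[N+](=O)[O-])c1ccc(/N=N\c2c[nH]c3ccccc23)cc1` gives 77900 nM, compound 2 `Cc1ccc(NC(=O)c2ccc(/N=N\c3c[nH]c4ccccc34)cc2)c(C)c1` gives 190000 nM, and compound 3 `O=C(Nc1ccccc1F)c1ccc(/N=N\c2c[nH]c3ccccc23)cc1` gives 106000 nM, which is the second highest of the three numbers and sits within the scatter of both others. Compound 4 `Cc1cccc(NC(=O)c2ccc(/N=N\c3c[nH]c4ccccc34)cc2)c1` differs from compound 3 by 3-methylphenyl in place of 2-fluorophenyl on an amide-type nitrogen. Among the compounds with values here, two measured steps bear on this change: a 1.8-fold lower number from compound 2 to compound 3 (0.25 log units; within the scatter) and a 2.4-fold higher number from compound 1 to compound 2 (0.39 log units; beyond the scatter), both small, and both pointing toward somewhat higher numbers where methyl groups sit on that ring. Compound 4 is therefore expected to shift by a 1.2-fold higher number from compound 3 to compound 4 (0.09 log units; within the scatter), a step that may well stay within the scatter. The estimate for compound 4 in this assay is 130000 nM, with a range from 60000 nM to 280000 nM.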

Compound 4, half-maximal inhibitory concentration: 300 nM
Compound 4: middle estimate off by 430-fold (2.64 log units), on the high side; the measured number lies below the stated range.
By their numbers in this assay, from the lowest: compound 4; then compounds 1, 3 and 2 (each within the scatter of the next, the first and the last beyond it).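

The group on the amide-type nitrogen can matter far more than the first three compounds suggested: 3-methylphenyl in place of 2-fluorophenyl gives a 350-fold lower number from compound 3 to compound 4 (2.55 log units; beyond the scatter) in this assay, and replacing 2-nitrophenyl gives a 260-fold lower number from compound 1 to compound 4 (2.41 log units; beyond the scatter) as well. A methyl on the ring is not enough on its own, since 2,4-dimethylphenyl also carries methyl groups, yet the change to 3-methylphenyl gives a 630-fold lower number from compound 2 to compound 4 (2.80 log units; beyond the scatter) in the same assay. Nothing available explains this large drop. From the compounds shown here alone, how a plain phenyl, a 3-ethylphenyl or a 3-aminophenyl group would compare at this place stays open.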